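The compounds below may be only part of what the source reports. "The series", "measured", "known", "first", "only" and "open" are said of these compounds alone.

Three compounds of this series carry a plasma protein binding result. In an ADME assay on a cell-free system (plasma, Homo sapiens) for protein binding, compound 1 `Cc1cc(Nc2ccc(S(F)(F)(F)(F)F)cc2)n2nc(C3CC3)nc2n1` gives 97.7%, compound 2 `Cc1cc(Nc2cccc(Cl)c2)n2nc(C(C)(F)F)nc2n1` gives 88.2%, and compound 3 `Cc1cc(Nc2ccc(C(F)(F)F)cc2)n2nc(C3CC3)nc2n1` gives 92.8%. Compound 3 holds the second highest unbound fraction of the three: its gap to compound 2 lies within the scatter, while the step a 3.1-fold higher unbound fraction from compound 1 to compound 3 (0.50 log units; beyond the scatter) lies beyond it.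

Compound 4 `Cc1cc(Nc2ccc(C(F)(F)F)cc2)n2nc(CCO)nc2n1` differs from compound 3 at a different site than that step: 2-hydroxyethyl in place of cyclopropyl on an aromatic carbon. For the measured compounds named here, no measured step touches the group on the five-membered ring, so nothing in the data calibrates this change; the only measured step, from compound 1 to compound 3, concerns another position. The expected step a 2.1-fold higher unbound fraction from compound 3 to compound 4 (0.32 log units; beyond the scatter) is a modest rise in unbound fraction. Compound 4 is estimated at 85%, range 74% to 92% in this assay.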

Compound 4, plasma protein binding: 67%
Compound 4: the middle estimate sits 2.2-fold (0.34 log units) (unbound fraction) below what was measured; measured number below the stated range.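

The group on the aromatic carbon of the five-membered ring now proves able to move the result in this assay: 2-hydroxyethyl in place of cyclopropyl gives a 4.6-fold higher unbound fraction from compound 3 to compound 4 (0.66 log units; beyond the scatter), beyond the scatter. This site therefore matters alongside the site of the earlier step, a 3.1-fold higher unbound fraction from compound 1 to compound 3 (0.50 log units; beyond the scatter), on the trifluoromethyl-bearing side. Nothing available explains the shift.

This single swap removes the ring and adds the hydroxyl together, so their shares stay unresolved. A propyl chain, a methoxyethyl group or an amine at this carbon would separate them.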